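A few compounds are considered here, and "the series" means these few. Any claim that something is new, unique, unknown or untested is made for them only; others in the source may bear on it.

Compound 3 `CC(=O)Nc1cccc2c(-c3cccc(NC(=O)c4ccc(Cl)c(C(F)(F)F)c4)c3)ccnc12` is tested in a functional assay on A375P cells (Homo sapiens) for antiproliferative activity, read by MTT assay, with a stated time of 48 h (a higher number here means a weaker inhibitor, a lower number a stronger inhibitor), where compound 3 gives 2400 nM. Of the two numbers shown this is the higher one, but compound 1 `Nc1cccc2c(-c3cccc(NC(=O)c4ccc(Cl)c(C(F)(F)F)c4)c3)ccnc12` gives 1400 nM, and the step of a 1.7-fold higher number from compound 1 to compound 3 (0.23 log units; within the scatter) lies within the scatter, so the two cannot be ranked. Compound 2 `Cc1cc(C(=O)Nc2cccc(-c3ccnc4c(N)cccc34)c2)c(C)o1` gives > 20000 nM, which is a limit of this assay and not a number, namely (the limit of > 20000 nM in this assay, at which 1 of the 3 values shown sits). Compound 4 `CC(=O)Nc1cccc2c(-c3cccc(NC(=O)c4cc5ccccc5s4)c3)ccnc12` differs from compound 3 in one place: 1-benzothiophen-2-yl in place of 4-chloro-3-(trifluoromethyl)phenyl on a carbonyl carbon. Going by the values given here, the only measured step, a 1.7-fold higher number from compound 1 to compound 3 (0.23 log units; within the scatter), concerns the acetyl on the aromatic amine, a different position, and offers little guidance for this change. Compound 1 and compound 2 differ in the acyl group, and their values show that a swap at that position can move a compound from a number to the limit. Compound 4 is therefore expected to give a higher number, with an estimated step of a 2.1-fold higher number from compound 3 to compound 4 (0.32 log units; beyond the scatter). The estimate for compound 4 in this assay is 5000 nM, with a range from 1500 nM to 20000 nM.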

Compound 4, half-maximal inhibitory concentration: 9100 nM
The estimate for compound 4 lay 1.8-fold (0.26 log units) below the measured number; the range from low to high includes it.
By their numbers in this assay, from the lowest: compounds 1 and 3 (each within the scatter of the next); then compound 4. At a limit, above all of these: compound 2.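

With the acetyl group kept in place, changing only the group on the amide carbonyl carbon gives a 3.8-fold higher number from compound 3 to compound 4 (0.58 log units; beyond the scatter) in this assay, so 1-benzothiophen-2-yl is a weaker choice here than 4-chloro-3-(trifluoromethyl)phenyl. The earlier step between two numbers, at the nitrogen on the aromatic ring, lay within the scatter, whereas this one is the first change among the compounds shown that can be read as a real loss of activity. Nothing measured here explains this loss.

Going by these compounds alone, only two groups with numerical values can be compared at this carbonyl carbon, so it remains open whether the chlorine, the trifluoromethyl or the ring type matters most. An unsubstituted phenyl, or a phenyl carrying only chlorine, could help separate these contributions, and it is also unknown whether the same change would behave alike with the free amine of compound 1.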